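A few compounds are considered here, and "the series" means these few. Any claim that something is new, unique, unknown or untested is made for them only; others in the source may bear on it.

Compound 3 `O=C(CS[C@H]1O[C@H](CO)[C@@H](O)[C@H](O)[C@H]1O)Nc1ccccc1` gives 3600000 nM in an assay on isolated protein (Oryctolagus cuniculus) for inhibition of glycogen phosphorylase, brain form (Homo sapiens) (a lower number here means a stronger inhibitor, a higher number a weaker inhibitor), the lowest of the three numbers measured. Compound 2 `NC(=O)CS[C@H]1O[C@H](CO)[C@@H](O)[C@H](O)[C@H]1O` gives 21100000 nM and compound 1 `[N-]=[N+]=NC[C@H]1O[C@H](CO)[C@@H](O)[C@H](O)[C@H]1O` gives 22400000 nM; between those two lies only a 1.1-fold lower number from compound 1 to compound 2 (0.03 log units; within the scatter), whereas a 5.9-fold lower number from compound 2 to compound 3 (0.77 log units; beyond the scatter) is a modest but real gain. Compound 4 `O=C(CS[C@H]1O[C@H](CO)[C@@H](O)[C@H](O)[C@H]1O)Nc1ccc(F)cc1F` carries 2,4-difluorophenyl in place of phenyl on an amide-type nitrogen. Going by the values given here, none of the measured steps alters a substituent on that phenyl ring, so the only guide is the modest size of a 5.9-fold lower number from compound 2 to compound 3 (0.77 log units; beyond the scatter), which this smaller change is unlikely to match. The expected shift is a 1.4-fold lower number from compound 3 to compound 4 (0.16 log units; within the scatter), small enough to remain within the scatter. The estimate for compound 4 is 2500000 nM, with a range from 900000 nM to 7000000 nM.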

Compound 4, inhibition constant: 18900000 nM
For compound 4 the middle estimate is 7.6-fold (0.88 log units) below the measured one; measured number outside the range, above it.
By their numbers in this assay, from the lowest: compound 3; then compounds 4, 2 and 1 (each within the scatter of the next).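

On the amide-type nitrogen, a small change to the aromatic ring matters: in this assay, 2,4-difluorophenyl in place of phenyl gives a 5.3-fold higher number from compound 3 to compound 4 (0.72 log units; beyond the scatter), so the modest gain from phenyl does not survive this change. Against the plain amide, the same group gives a 1.1-fold lower number from compound 2 to compound 4 (0.05 log units; within the scatter), which leaves no gain at all. Nothing available explains why the two fluorine atoms have this effect.

As far as these compounds go, whether one fluorine alone would do the same remains open, and so does what a methyl or a chlorine on that phenyl ring would do.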